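This account rests on a few compounds, and the source may have more. Where it says the series, first, only, none or still open, it means among the compounds named here.

In a physicochemical assay for solubility (a lower number here means a less soluble compound, a higher number a more soluble compound), compound 1 `O=C(Cn1ccnc1)N1CCC(NS(=O)(=O)c2cc(S(=O)(=O)c3ccccc3)ccc2C(F)(F)F)CC1` gives 100000 nM, compound 2 `CC(C)(C)OC(=O)N1CCC[C@H]1C(=O)N1CCC(NS(=O)(=O)c2cc(S(=O)(=O)c3ccccc3)ccc2C(F)(F)F)CC1` gives 25000 nM and compound 3 `O=C1CC[C@@H](C(=O)N2CCC(NS(=O)(=O)c3cc(S(=O)(=O)c4ccccc4)ccc3C(F)(F)F)CC2)N1` gives 100000 nM. Compound 3 is thus level with compound 1, and together they hold the highest number of the three. Compound 4 `CC(=O)N1CCC[C@H]1C(=O)N1CCC(NS(=O)(=O)c2cc(S(=O)(=O)c3ccccc3)ccc2C(F)(F)F)CC1` differs from compound 3 by 1-acetylpyrrolidin-2-yl in place of 5-oxopyrrolidin-2-yl on a carbonyl carbon. Among the compounds with values here, the entering group, 1-acetylpyrrolidin-2-yl, shares its name pattern with the 1-(tert-butoxycarbonyl)pyrrolidin-2-yl group, the only group here tied to a lower number: a 4.0-fold lower number from compound 1 to compound 2 (0.60 log units; beyond the scatter), and a 4.0-fold higher number from compound 2 to compound 3 (0.60 log units; beyond the scatter). By contrast, no change at the digits printed from compound 1 to compound 3 (within the scatter). With the smaller acetyl group, a step in the same lower direction is expected, but smaller than those, around the edge of the scatter. The expected step is a 1.8-fold lower number from compound 3 to compound 4 (0.26 log units; within the scatter). Compound 4 is estimated at 55000 nM, with an expected range of 25000 nM to 100000 nM.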

Compound 4, solubility: 12500 nM
Compound 4: middle estimate off by 4.4-fold (0.64 log units), on the high side; measured number outside the range, below it.
By their numbers in this assay, from the lowest: compounds 4 and 2 (each within the scatter of the next); then compounds 1 and 3 (each within the scatter of the next).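

In this assay, 1-acetylpyrrolidin-2-yl on this carbonyl carbon does not behave like 5-oxopyrrolidin-2-yl, giving an 8.0-fold lower number from compound 3 to compound 4 (0.90 log units; beyond the scatter), and it also falls short of (1H-imidazol-1-yl)methyl, with an 8.0-fold lower number from compound 1 to compound 4 (0.90 log units; beyond the scatter). Methyl in place of tert-butoxy on the carbonyl carbon gives a 2.0-fold lower number from compound 2 to compound 4 (0.30 log units; within the scatter), so shortening this acyl group does not separate the two compounds. Nothing measured here accounts for the gap between the groups.

Open, on these data alone, is whether a free amine on the pyrrolidin-2-yl ring, or a carboxylic acid in place of the acetyl group, would match compound 3 or stay with compound 4.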